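The compounds below may be only part of what the source reports. "The series", "measured", "known", "first", "only" and "open" are said of these compounds alone.

Two compounds of the series, compound 1 `COc1ccc(-c2cc(/C=C/C(=O)c3ccc(N)cc3)[nH]n2)cc1` and compound 2 `COc1cc(-c2cc(/C=C/C(=O)c3ccc(N)cc3)[nH]n2)cc(OC)c1OC`, have been run so far. In a functional assay on PC-3 cells (Homo sapiens) for cytotoxicity, read by sulforhodamine B assay, with a stated time of 48 h, tested at 0.01 uM (a lower number here means a stronger effect, a higher number a weaker effect of the compound at the concentration tested), compound 1 gives 95% and compound 2 gives 97%. The number for compound 2 lies within the scatter of that for compound 1, so the two cannot be told apart here. Compound 3 `COc1ccc(-c2cc(/C=C/C(=O)c3ccc(N)cc3)[nH]n2)cc1OC` remains to be measured; it differs from compound 2 by hydrogen in place of methoxy on an aromatic carbon. For the measured compounds named here, with no step between measured compounds to lean on, the step of a number 2 percentage points lower from compound 2 to compound 3 (within the scatter) is expected to stay within the scatter. Compound 3 is therefore estimated at 95%, with a range of 85% to 100%.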

Compound 3, a percentage reported as activity, at one concentration (the size of the read-out at that concentration, not a potency): 95%
For compound 3 middle estimate and measured number coincide at the digits printed; the measured number falls inside the stated range.
By their numbers in this assay, from the lowest: compounds 1, 3 and 2 (each within the scatter of the next).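

Hydrogen in place of methoxy on this aromatic carbon, ortho to a methoxy group, gives a number 2 percentage points lower from compound 2 to compound 3 (within the scatter) in this assay, while methoxy in place of hydrogen on an aromatic carbon gives no change at the digits printed from compound 1 to compound 3 (within the scatter). For the compounds shown here, these are the first single-place steps, and neither separates the compounds it joins at the one concentration tested. Nothing available bears on an explanation for this.

Going by these compounds, whether a hydroxyl, an amine or a chlorine at this position would shift the read-out remains open. Also open, on these data alone, is whether these compounds differ at higher concentrations.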